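Swapping the side chain on the butyl sulfonamide

The source may report more compounds than this note shows. Statements on the series, on what has been measured and on what is new or still open speak of the compounds shown alone.

Measured in a functional assay on SNU-638 cells (Homo sapiens) for antiproliferative activity, read by sulforhodamine B assay, with a stated time of 72 h; a higher number here means a weaker inhibitor, a lower number a stronger inhibitor:
- compound 1 `COc1ncc(-c2ccc3c(c2)N(Cc2ccncc2)C(=O)CO3)cc1NS(=O)(=O)c1ccc(F)cc1F`: 6960 nM
- compound 2 `COc1ncc(-c2ccc3c(c2)N(CCCn2ccccc2=O)C(=O)CO3)cc1NS(=O)(=O)c1ccc(F)cc1F`: 6760 nM
- compound 3 `CCCCS(=O)(=O)Nc1cc(-c2ccc3c(c2)N(Cc2ccncc2)C(=O)CO3)cnc1OC`: 46500 nM

Compound 3 has the highest number of the three, and so is the weakest inhibitor here. It is set apart by a 6.7-fold higher number from compound 1 to compound 3 (0.82 log units; beyond the scatter), which replaces 2,4-difluorophenyl with butyl on a sulfonyl sulfur.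

Compound 4 `CCCCS(=O)(=O)Nc1cc(-c2ccc3c(c2)N(CCCN(C)C)C(=O)CO3)cnc1OC` keeps the butyl group and differs from compound 3 by 2-(dimethylamino)ethyl in place of pyridin-4-yl on a saturated chain carbon bound to an amide-type nitrogen in a ring. Cut one bond further out, this reads (pyridin-4-yl)methyl to 3-(dimethylamino)propyl.

For the measured compounds named here, only one measured step changes this place: a 1.0-fold lower number from compound 1 to compound 2 (0.01 log units; within the scatter). It lies within the scatter, although it has a different entering group and carries the 2,4-difluorophenyl group. The step to compound 3 concerns the sulfonyl sulfur and says nothing direct about this place. Going by the values given here, no measured compound carries 3-(dimethylamino)propyl, so the basis is thin.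

The expected step, with no shift beyond the scatter, is a 1.3-fold lower number from compound 3 to compound 4 (0.12 log units; within the scatter). Compound 4 is estimated at 35000 nM, with an expected range of 12000 nM to 90000 nM.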

Compound 4, half-maximal inhibitory concentration: 8970 nM
Compound 4: middle estimate off by 3.9-fold (0.59 log units), on the high side; the whole stated range lies above it.
By their numbers in this assay, from the lowest: compounds 2, 1 and 4 (each within the scatter of the next); then compound 3.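

In this assay, this place on a saturated chain carbon bound to an amide-type nitrogen in a ring now shows a shift beyond the scatter on the butyl sulfonamide, with a 5.2-fold lower number from compound 3 to compound 4 (0.71 log units; beyond the scatter) for 3-(dimethylamino)propyl in place of (pyridin-4-yl)methyl. For the compounds shown here, the only earlier step at this place, a 1.0-fold lower number from compound 1 to compound 2 (0.01 log units; within the scatter) on the 2,4-difluorophenyl sulfonamide, lay within the scatter, so the side chain is not silent across the series, although the two steps differ in both the entering group and the sulfonyl substituent. Nothing available accounts for the shift at this place.

Going by these compounds, whether 3-(dimethylamino)propyl gives a similar step on the 2,4-difluorophenyl sulfonamide remains open. Also open, on these data alone, is whether the result depends on the dimethylamino group itself, which a morpholine, a primary amine or a carboxylic acid on the same chain, or a longer chain, could test.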